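Isopropoxy for Trifluoromethylcyclopropyl: Expected Clearance of Compound 3

The compounds below may be only part of what the source reports. "The series", "measured", "known", "first", "only" and "open" are said of these compounds alone.

Measured compounds:
compound 1 `CC(C)(C)c1ccc(C(=O)NCc2c(F)cc(NS(C)(=O)=O)cc2F)cc1` — 9.3 mL.min-1.g-1
compound 2 `CS(=O)(=O)Nc1ccc(CNC(=O)c2ccc(C3(C(F)(F)F)CC3)cc2)c(Cl)c1` — 7.5 mL.min-1.g-1

In an ADME assay on microsomes from liver (Rattus norvegicus, strain Sprague-Dawley) for metabolic stability, read by HPLC, using NADPH, with stated times of 5 min and 60 min, tested at 10 uM (on this read-out higher numbers stand for fast clearance and lower numbers for slow clearance), compound 2 gives 7.5 mL.min-1.g-1, the lower of the two numbers. Its nearest neighbour is compound 1, whose number is higher but lies within the scatter, so the two compounds cannot be ranked against each other on this read-out.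

Compound 3 `CC(C)Oc1ccc(C(=O)NCc2ccc(NS(C)(=O)=O)cc2Cl)cc1` is not yet measured. It differs from compound 2 in one place: isopropoxy in place of 1-(trifluoromethyl)cyclopropyl on an aromatic carbon, para to a large group on the shared core. Within the data shown here, no measured pair follows this same change, so nothing in the numbers fixes its direction or size.

On the structural change alone, compound 3 is expected to give 14 mL.min-1.g-1 in this assay, with a range from 7 mL.min-1.g-1 to 28 mL.min-1.g-1. This estimate means a step of a 1.9-fold higher number from compound 2 to compound 3 (0.27 log units; within the scatter), expected toward faster clearance and somewhat beyond the scatter.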

Compound 3, intrinsic clearance in microsomes: 12 mL.min-1.g-1
Beside the measured number, compound 3's estimate is 1.2-fold (0.07 log units) above it, and the stated range covers the measured number.
By their numbers in this assay, from the lowest: compounds 2, 1 and 3 (each within the scatter of the next).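

In this assay, among these compounds, isopropoxy in place of 1-(trifluoromethyl)cyclopropyl on an aromatic carbon, para to a large group, gives a 1.6-fold higher number from compound 2 to compound 3 (0.20 log units; within the scatter), the first measured step at this position. Here a group with no ring and one hydrogen-bond acceptor and a group with a three-membered ring and no such acceptor cannot be told apart on this read-out, so the change shows no clear effect on clearance. No measurement shown here bears on why the two groups cannot be separated.

Going by these compounds, it remains open whether an amine, a carboxylic acid or a longer alkoxy chain at this position would give a step beyond the scatter. Also open, on these data alone, is whether this same change would read alike on the core of compound 1.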